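Benzylic amide series: methoxy to fluoro step

The compounds below may be only part of what the source reports. "The series", "measured", "known", "first", "only" and "open" are said of these compounds alone.

Measured so far in a functional assay on A549 cells (Homo sapiens) for inhibition, read by MTT assay, with a stated time of 48 h; a lower number here means a stronger inhibitor, a higher number a weaker inhibitor:
compound 1 `COc1ccc(CNC(=O)/C=C/c2coc3cc(O)ccc3c2=O)cc1` gives > 100000 nM
compound 2 `COc1ccc2c(=O)c(/C=C/C(=O)Nc3cc(C)ccc3C)coc2c1` gives 15500 nM
compound 3 `COc1cccc(NC(=O)/C=C/c2coc3cc(OC)ccc3c2=O)c1` gives 12800 nM

Compound 1 stands only at a limit of this assay, not at a number, as the evidence shows: the limit of > 100000 nM in this assay, at which 1 of the 3 values shown sits. For the measured compounds named here, compound 2 and compound 3 give numbers, and the single measured step between them, a 1.2-fold lower number from compound 2 to compound 3 (0.08 log units; within the scatter), lies within the scatter and concerns the group on the amide-type nitrogen.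

Compound 4 `O=C(/C=C/c1coc2cc(O)ccc2c1=O)NCc1ccc(F)cc1` differs from compound 1 in one place: fluoro in place of methoxy on an aromatic carbon. Going by the values given here, no measured step touches this position; the step from compound 2 to compound 3 changes a different part of the molecule, so it gives no direction for the present change. The starting point of compound 1 is a limit rather than a number. Compound 4 is therefore expected to remain near that limit, the estimate being 100000 nM with a range from 30000 nM to 400000 nM. The step this expectation means, a number no higher from compound 1 to compound 4 (the limit leaves the size open), is expected to be small, and a reported limit is the likelier outcome.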

Compound 4, half-maximal inhibitory concentration: > 100000 nM
Compound 4 ended at the assay's limit; the forecaster's own chance of this, stated with the estimate: 60%; the middle value sits exactly at the limit.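

Compound 1 and compound 4 both stand at a limit of this assay, so no step between them can be read: the limit of > 100000 nM in this assay, at which 2 of the 4 values shown sit.

The compounds shown leave open whether fluoro in place of methoxy on an aromatic carbon shifts the number at all in this benzylic amide pair.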